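The source may hold more compounds than are shown below. What is called first, only, known or untested is meant among the compounds shown, and "the series" means these compounds.

Series notes

Both measured compounds were run in a functional assay on the whole organism (Tail, strain ICR) with Mus musculus as the target, in the tail flick test, with a stated time of 90 min, at a dose of 25 umol/kg by the oral route; a higher number here means a stronger effect of the compound at the dose given, a lower number a weaker effect.
compound 1 `C[C@@H](O)[C@H](NC(=O)CN(c1nc(Cl)nc2[nH]cnc12)C1CC1)C(=O)OCc1ccccc1`: compound 1 gives 29.9%
compound 2 `O=C(CN(c1ncnc2c1ncn2C1CCCCO1)C1CC1)N[C@@H](CO)C(=O)OCc1ccccc1`: compound 2 gives 32.2%

Compound 2 carries the higher of the two numbers, but compound 1 sits within the scatter of it, so the two cannot be told apart on this assay. Among the measured compounds shown here, no pair of measured compounds differs in only one place, so no step is available from the data.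

Compound 3 `CC(C)[C@H](NC(=O)CN(c1ncnc2c1ncn2C1CCCCO1)C1CC1)C(=O)OCc1ccccc1` is not yet measured. It differs from compound 2 as follows: isopropyl in place of hydroxymethyl on a saturated chain carbon bound to an amide-type nitrogen and a carbonyl carbon. For the measured compounds named here, nothing among the measured compounds shows how this change plays out; the only guide is that compound 1 and compound 2, which differ in more than one place, give numbers within the scatter of each other. The step of a number 2.2 percentage points lower from compound 2 to compound 3 (within the scatter) is therefore expected to be small, none beyond the scatter in either direction. Compound 3 is estimated at 30%, with a range from 12% to 50%.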

Compound 3, a percentage reported as activity, at one dose (the size of the read-out at that dose, not a potency): 30.1%
Compound 3: middle estimate off by 0.1 percentage points, on the low side, within the range that was stated.
By their numbers in this assay, from the lowest: compounds 1, 3 and 2 (each within the scatter of the next).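

Among the compounds shown here, at the saturated chain carbon bound to an amide-type nitrogen and a carbonyl carbon, isopropyl in place of hydroxymethyl provides the only comparison that differs in one place: in this assay, it gives a number 2.1 percentage points lower from compound 2 to compound 3 (within the scatter). Isopropyl has none of the hydrogen-bond donors or acceptors counted on hydroxymethyl, yet this one pair cannot be told apart at the dose tested. No supporting data bear on the reason for this result.

As far as these compounds go, whether an amine, a carboxylic acid or a longer chain at this place would give a step beyond the scatter remains open. Also open, from the compounds shown here alone, is whether isopropyl in place of hydroxymethyl would read the same way on the core of compound 1.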